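The source may hold more compounds than are shown below. What is called first, only, known or untested is meant among the compounds shown, and "the series" means these compounds.

Compound 1 `COc1cc2oc(-c3ccccc3)cc(=O)c2c(O)c1OCCCN1CCCC1` carries a pyrrolidin-1-yl group and in a functional assay on HepG2 cells (Homo sapiens) for antiproliferative activity, read by MTT assay, with a stated time of 48 h (a higher number here means a weaker inhibitor, a lower number a stronger inhibitor), gives 4300 nM. Compound 3 `CCN(CC)CCCOc1c(OC)cc2oc(-c3ccccc3)cc(=O)c2c1O` differs from it by diethylamino in place of pyrrolidin-1-yl on a saturated chain carbon, three bonds along the chain from an oxygen on an aromatic ring. In this assay compound 3 gives 3700 nM, which makes a step of a 1.2-fold lower number from compound 1 to compound 3 (0.07 log units; within the scatter). Compound 2 `O=c1cc(-c2ccccc2)oc2cc(OCc3ccccc3)c(OCCCCN3CCCC3)c(O)c12` has a different core; the difference between the two cores is not broken down here. In this assay compound 2 gives 2000 nM. Compound 4 `CCN(CC)CCCCOc1c(OCc2ccccc2)cc2oc(-c3ccccc3)cc(=O)c2c1O` is not yet measured and differs from compound 2 by diethylamino in place of pyrrolidin-1-yl on a saturated chain carbon, four bonds along the chain from an oxygen on an aromatic ring. This is the same kind of change as that from compound 1 to compound 3, though not the same: there the place is on a saturated chain carbon, three bonds along the chain from an oxygen on an aromatic ring, here it is four bonds along the chain. Since the measured step of a 1.2-fold lower number from compound 1 to compound 3 (0.07 log units; within the scatter) lies within the scatter, the change on the core of compound 2 is expected to give a similarly small step, a 1.2-fold lower number from compound 2 to compound 4 (0.07 log units; within the scatter). Compound 4 is therefore estimated at 1700 nM, with an expected range of 900 nM to 3500 nM, resting on compound 2 at 2000 nM.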

Compound 4, half-maximal inhibitory concentration: 2200 nM
Estimate against measurement, compound 4: 1.3-fold (0.11 log units) below; the measured number falls inside the stated range.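

In this assay, diethylamino in place of pyrrolidin-1-yl on the core of compound 2 gives a 1.1-fold higher number from compound 2 to compound 4 (0.04 log units; within the scatter), so the change has no readable effect on this core. Set beside the earlier step, the change reads the same on both cores: the same change on two cores in this assay, a 1.2-fold lower number (0.07 log units; within the scatter) from compound 1 to compound 3 and a 1.1-fold higher number (0.04 log units; within the scatter) from compound 2 to compound 4, 1.3-fold (0.11 log units) apart, within the scatter of two such steps. This shows that, in these two pairs, the exchange of the two amines can be carried from one core to the other without a step beyond the scatter, but it does not show that a step of real size would carry over, since neither pair gives one, and two pairs set no rule for the series.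

Still open, going by these compounds, is whether a piperidine, a morpholine or a dimethylamino group on the same chain would give a step beyond the scatter. Also open, on these data alone, is whether a chain longer than the 4-(diethylamino)butyl chain of compound 4 would keep the two amines level in this assay.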